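Chloro scan on two sulfonyl thiourea-type cores

This account rests on a few compounds, and the source may have more. Where it says the series, first, only, none or still open, it means among the compounds named here.

The first pair shares one core. Compound 1 is `O=[N+]([O-])c1ccc(Oc2c(Cl)cc(S(=O)(=O)N/C(=N\O)Nc3ccc(Cl)cc3)cc2Cl)cc1` and in a functional assay on COLO 205 cells (Homo sapiens) for cytotoxicity (a lower number here means a stronger inhibitor, a higher number a weaker inhibitor), compound 1 gives 12 ug/mL. Compound 2 is `O=[N+]([O-])c1ccc(Oc2c(Cl)cc(S(=O)(=O)N/C(=N\O)Nc3ccc(Cl)cc3)cc2Cl)c(Cl)c1`; in this assay compound 2 gives 6 ug/mL. The change between them is chloro in place of hydrogen on an aromatic carbon and its size is a 2.0-fold lower number from compound 1 to compound 2 (0.30 log units; within the scatter).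

Compound 3, `Cc1ccc(S(=O)(=O)/N=C(\S)Nc2ccc(Cl)cc2)cc1`, stands on a different core; the difference between the two cores is not broken down here. In this assay compound 3 gives 87 ug/mL, the highest number of the three measured, with the step to compound 1 and the step to compound 2 both beyond the scatter.

Compound 4 is `Cc1ccc(S(=O)(=O)/N=C(\S)Nc2ccc(Cl)c(Cl)c2)cc1`, not yet measured. Relative to compound 3 the change is chloro in place of hydrogen on an aromatic carbon. Among the measured compounds shown here, this is the same kind of change as the one from compound 1 to compound 2, but the surroundings differ: there the entering chloro sat ortho to a large group and meta to a nitro group, here it sits ortho to a chloro group and meta to a large group.

For the measured compounds named here, only one prior instance of this change exists, and it lies within the scatter, so the expectation for compound 4 is a small step at most: the step from compound 3 to compound 4 in this assay is estimated as a 1.7-fold lower number from compound 3 to compound 4 (0.24 log units; within the scatter), resting on the one earlier step of a 2.0-fold lower number from compound 1 to compound 2 (0.30 log units; within the scatter). For compound 4 the estimated value in this assay is 50 ug/mL, expected to fall between 20 ug/mL and 120 ug/mL.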

Compound 4, half-maximal inhibitory concentration: 45 ug/mL
For compound 4 the middle estimate is 1.1-fold (0.05 log units) above the measured one; low and high end bracket the measured number.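

In this assay, chloro in place of hydrogen on an aromatic carbon, here ortho to a chloro group and meta to a large group, gives a 1.9-fold lower number from compound 3 to compound 4 (0.29 log units; within the scatter), so on the core of compound 3 the step again stays inside the scatter. Set beside the earlier step, the change carries from one core to the other with a step of matching size: the same change on two cores in this assay, a 2.0-fold lower number (0.30 log units; within the scatter) from compound 1 to compound 2 and a 1.9-fold lower number (0.29 log units; within the scatter) from compound 3 to compound 4, 1.0-fold (0.01 log units) apart, within the scatter of two such steps

This does not show that the chloro has a real effect on the number in either core, as each step taken alone lies within the scatter, and two pairs in a single assay give no general rule for the series.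

The compounds shown leave open whether another group at this place, such as an amine, a carboxylic acid or a methoxy group, would give a step beyond the scatter. They also leave open which part of the two cores carries the difference between them, as no pair shown links the cores through a change in one place.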